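Swapping 3-fluorophenyl for (pyridin-2-yl)oxy on a saturated ring carbon

The compounds below may be only part of what the source reports. "The series", "measured", "known", "first", "only" and "open" are said of these compounds alone.

Among the compounds with values here, in an ADME assay on liver (Mesocricetus auratus) for metabolic stability, using microsomes (a higher number here means faster removal of the compound, a lower number slower removal), three compounds have numbers so far. Compound 1 (`O=C(Nc1cc(-c2ccccn2)n[nH]1)N1CCC(c2cccc(F)c2)CC1`) gives 207 mL.min-1.g-1 and stands second highest of the three. Compound 3 (`O=C(NCc1cccc(Cl)c1)Nc1cc(-c2ccccn2)n[nH]1`) gives 434 mL.min-1.g-1 as the highest number, and compound 2 (`O=C(Nc1cc(-c2ccccn2)n[nH]1)N1CCN(c2ccc(F)cc2)CC1`) gives 46.5 mL.min-1.g-1 as the lowest. Both gaps to compound 1 lie beyond the scatter.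

Compound 4 (`O=C(Nc1cc(-c2ccccn2)n[nH]1)N1CCC(Oc2ccccn2)CC1`) has not yet been measured. It keeps the rest of compound 1 but carries (pyridin-2-yl)oxy in place of 3-fluorophenyl on a saturated ring carbon. Within the data shown here, no measured pair shows this change on its own, and the three measured compounds differ from one another in more than one place, so the size of the step cannot be read directly. Among the measured compounds shown here, the only guide is the spread of the numbers, whose lower end is compound 2 at 46.5 mL.min-1.g-1 so far. A moderate fall from compound 1 is the working expectation, held loosely. In this assay the expected step is a 2.3-fold lower number from compound 1 to compound 4 (0.36 log units; beyond the scatter) and it points to a lower number. In this assay compound 4 is estimated at 90 mL.min-1.g-1 with 40 mL.min-1.g-1 to 220 mL.min-1.g-1 as the expected range.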

Compound 4, intrinsic clearance in microsomes: 67.3 mL.min-1.g-1
For compound 4 the middle estimate is 1.3-fold (0.13 log units) above the measured one; measured number inside the range.
By their numbers in this assay, from the lowest: compounds 2 and 4 (each within the scatter of the next); then compound 1; then compound 3.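

Within the data shown here, the exchange of 3-fluorophenyl for (pyridin-2-yl)oxy gives the first step in this assay that can be read at a single place, a 3.1-fold lower number from compound 1 to compound 4 (0.49 log units; beyond the scatter). It shows that the number responds to the group on this saturated ring carbon, three ring bonds from the ring nitrogen, while the rest of compound 1 stays fixed. The two groups match in their count of heavy atoms, so the step comes with a change in the kind of atoms rather than in that count, but nothing measured here accounts for the fall.

The exchange adds an oxygen link, places a nitrogen in the aromatic ring and removes the fluorine all at once, so the compounds shown leave open which of these changes carries the step; a phenoxy or 3-fluorophenoxy group on the same carbon would begin to separate them. They also leave open whether a saturated group on this carbon, such as a morpholine or a simple amine, would give a step of similar size and direction.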